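The source may hold more compounds than are shown below. What is called first, only, known or untested is meant among the compounds shown, and "the series" means these compounds.

Measured so far in a functional assay on MDA-MB-231 cells (Homo sapiens) for antiproliferative activity, read by MTT assay; a higher number here means a weaker inhibitor, a lower number a stronger inhibitor:
compound 1 `CCCCCCCCCCCCCCCc1cc(=O)c2c(O)c(C)c(OCOC)cc2o1`, a limit of the assay rather than a number, > 87000 nM
compound 2 `CCCCCCCCCCCCCCCc1cc(=O)c2c(O)cc(O)c(C)c2o1`, 6790 nM
compound 3 `CC/C=C\C/C=C\C/C=C\CCCCCCCc1cc(=O)c2c(O)c(C)c(OCOC)cc2o1`, 6790 nM

Compound 3 differs from compound 1 in one place: a group of 10 heavy atoms (10 carbon; no ring) in place of a group of 8 heavy atoms (8 carbon; no ring), on a saturated chain carbon, seven bonds along the chain from an aromatic carbon. This change gave an at least 12-fold lower number from compound 1 to compound 3 (1.10 log units; beyond the scatter), a size known only as a lower bound because of the limit of > 87000 nM in this assay, at which 1 of the 3 values shown sits. Compound 2 has a different core; how its core differs from that of compound 1 is not broken down here. In this assay compound 2 and compound 3 sit level, within the usual scatter.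

Compound 4 `CC/C=C\C/C=C\C/C=C\CCCCCCCc1cc(=O)c2c(O)cc(O)c(C)c2o1` has not yet been measured in this assay. It differs from compound 2 by a group of 10 heavy atoms (10 carbon; no ring) in place of a group of 8 heavy atoms (8 carbon; no ring), on a saturated chain carbon, seven bonds along the chain from an aromatic carbon, the same change at the same place that turned compound 1 into compound 3. On these data alone, the earlier step began at a limit, and its true size is unknown; compound 2 already stands level with compound 3, so little rests behind any prediction. For compound 4 the expected step in this assay is a 2.7-fold lower number from compound 2 to compound 4 (0.43 log units; beyond the scatter). Compound 4 is therefore estimated at 2500 nM, with a likely range from 500 nM to 10000 nM.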

Compound 4, half-maximal inhibitory concentration: 6790 nM
Beside the measured number, compound 4's estimate is 2.7-fold (0.43 log units) below it; the range from low to high includes it.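

Replacing the octyl group with the longer chain carrying three double bonds gave no change at the digits printed from compound 2 to compound 4 (within the scatter) in this assay, so this change did nothing measurable on the core of compound 2. Its effect therefore did not carry over from the core of compound 1 to the core of compound 2, and the effect seen on one core cannot be assumed on the other: the same change on two cores in this assay, an at least 12-fold lower number (1.10 log units; beyond the scatter) from compound 1 to compound 3 and no change at the digits printed (within the scatter) from compound 2 to compound 4, at least 12-fold (1.10 log units) apart, beyond the scatter of two such steps

Compound 1 sits at a limit of the assay rather than at a number, so the earlier step and the gap between the two steps are known only as minimum sizes, and two cores cannot show how the change would behave on any further core: the limit of > 87000 nM in this assay, at which 1 of the 4 values shown sits.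

The compounds shown leave open whether the double bonds or the extra chain length drove the earlier step, which a longer saturated chain could help separate. They also leave open whether a chain carrying an amine or a carboxylic acid would shift the number on either core.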